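Splenocyte series: oxadiazole-linked aryl pairs, next step

The source may report more compounds than this note shows. Statements on the series, on what has been measured and on what is new or still open speak of the compounds shown alone.

Of the compounds shown here, three carry numbers so far. Compound 1 `Fc1ccc(-c2noc(Cc3c[nH]c4ccccc34)n2)cc1` gives 13600 nM in a functional assay on cells (Splenocyte, Mus musculus, strain BALB/c) for inhibition, read by scintillation counting and thymidine incorporation, with stated times of 48 h and 8 h (on this read-out higher numbers stand for weaker inhibition and lower numbers for stronger inhibition), and compound 2 `COc1cccc(-c2nc(Cc3c[nH]c4ccccc34)no2)c1` gives 11100 nM in this assay. Compound 3 `COc1cc(-c2noc(-c3ccc(NC(=O)OC(C)(C)C)cc3)n2)cc(OC)c1OC` gives 2200 nM in this assay, the lowest of the three numbers; its nearest neighbour is compound 2, and both compounds 1 and 2 sit beyond the scatter from it. Compounds 1 and 2 also differ from compound 3 in more than one place, so no single step can be read out of those pairs.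

Compound 4 `CCc1ccc(-c2nc(-c3cc(OC)c(OC)c(OC)c3)no2)cc1` is not yet measured. It differs from compound 3 in one place: ethyl in place of (tert-butoxycarbonyl)amino on an aromatic carbon on an aromatic carbon of a six-membered aromatic ring of carbon only, para to a large group. For the measured compounds named here, no measured pair in the set reports a step of this kind, so the expectation rests on compound 3 alone. A small step is expected from compound 3 to compound 4, a 1.6-fold higher number from compound 3 to compound 4 (0.20 log units; within the scatter), toward a weaker number but close to the scatter. Compound 4 is expected at 3500 nM, within a range of 1200 nM to 12000 nM in this assay.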

Compound 4, half-maximal inhibitory concentration: > 50000 nM
Compound 4 was reported as a limit (the forecaster's own chance of this, stated with the estimate: 5%); at least 14-fold (1.15 log units) between middle value and limit.
By their numbers in this assay, from the lowest: compound 3; then compounds 2 and 1 (each within the scatter of the next). At a limit, above all of these: compound 4.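

In this assay compound 4 gives > 50000 nM, which is a limit of the assay and not a number. Ethyl in place of (tert-butoxycarbonyl)amino on this aromatic carbon, para to a large group, gives an at least 22-fold higher number from compound 3 to compound 4 (1.35 log units; beyond the scatter), the first single-place step in the series, so the group held at this position matters strongly for the read-out with the rest of compound 3 unchanged. The size of that step is only a bound: the limit of > 50000 nM in this assay, at which 1 of the 4 values shown sits.

Which part of the (tert-butoxycarbonyl)amino group carries the difference remains open, since the two compounds compare only the whole group against ethyl. Also open, going by these compounds, is whether a free amine, an acetamide or a longer alkyl chain on this carbon would read close to compound 3 or close to compound 4.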